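Lengthening a chain between two amides: inhibition stays absent

The source may hold more compounds than are shown below. What is called first, only, known or untested is meant among the compounds shown, and "the series" means these compounds.

Of the compounds shown here, three built on a shared core have been tested in an assay on isolated protein for inhibition of hexokinase-3 (Rattus norvegicus), with a stated time of 6 h, tested at 10 mM; a lower number here means less inhibition, a higher number more inhibition at the concentration tested (going by the name of the read-out). Compound 1 is `O=C(CI)NCCCCCC(=O)NCCCCCCNc1ncnc2c1ncn2[C@@H]1O[C@H](COP(=O)(O)OP(=O)(O)OP(=O)(O)O)[C@@H](O)[C@H]1O` and in this assay compound 1 gives 0%. Compound 2 is `O=C(CI)NCCCCC(=O)NCCCCCCNc1ncnc2c1ncn2[C@@H]1O[C@H](COP(=O)(O)OP(=O)(O)OP(=O)(O)O)[C@@H](O)[C@H]1O` and compound 2 gives 0%. Compound 3 is `O=C(CI)NCCCCCC(=O)NCCCNc1ncnc2c1ncn2[C@@H]1O[C@H](COP(=O)(O)OP(=O)(O)OP(=O)(O)O)[C@@H](O)[C@H]1O` and compound 3 gives 0%.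

Compound 2 and compound 1 differ in one place: (((iodomethyl)carbonyl)amino)methyl in place of ((iodomethyl)carbonyl)amino on a saturated chain carbon, four bonds along the chain from a carbonyl carbon. That change gives no change at the digits printed from compound 2 to compound 1 (within the scatter). How the core of compound 3 differs from the core of compound 2 is not broken down here; their two values are simply level at the digits given. Compound 3 also sits level with compound 1 at the digits given, so none of the three is set apart from the others.

Compound 4, `O=C(CI)NCCCCCCC(=O)NCCCNc1ncnc2c1ncn2[C@@H]1O[C@H](COP(=O)(O)OP(=O)(O)OP(=O)(O)O)[C@@H](O)[C@H]1O`, has not yet been measured. It differs from compound 3 by (((iodomethyl)carbonyl)amino)methyl in place of ((iodomethyl)carbonyl)amino on a saturated chain carbon, five bonds along the chain from a carbonyl carbon. Within the data shown here, this is the same kind of change as the one from compound 2 to compound 1, but the place is not the same: in the earlier pair the change sits four bonds along the chain from a carbonyl carbon, whereas here it sits five bonds along the chain from a carbonyl carbon. Because the earlier step of no change at the digits printed from compound 2 to compound 1 (within the scatter) left the read-out unmoved, and because compound 3 gives 0%, the expected step from compound 3 to compound 4 is no change at the digits printed from compound 3 to compound 4 (within the scatter). On that basis compound 4 is estimated at 0%, with an expected range from -5% to 10%.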

Compound 4, a percentage reported as inhibition, at one concentration (the size of the read-out at that concentration, not a potency): 0%
The estimate for compound 4 equals the measured number at the digits printed; measured number inside the range.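

In this assay, putting (((iodomethyl)carbonyl)amino)methyl in place of ((iodomethyl)carbonyl)amino on a saturated chain carbon, five bonds along the chain from a carbonyl carbon, gives no change at the digits printed from compound 3 to compound 4 (within the scatter). Set beside the earlier step on the other core, the same kind of change reads alike, although its place on the chain is not the same: the same change on two cores in this assay, no change at the digits printed (within the scatter) from compound 2 to compound 1 and no change at the digits printed (within the scatter) from compound 3 to compound 4, 0 percentage points apart, within the scatter of two such steps. This shows that the change brought no detectable inhibition on either core at the concentration tested, but with compound 4 at 0% and the other three compounds level with it, neither step starts from a measurable effect, so the agreement cannot show how the change would act on a compound that does inhibit the enzyme.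

The compounds shown leave open whether any member of this series can give a reading that differs from the others, and so whether a change in chain length matters at all in this assay. A longer chain than 4-(((iodomethyl)carbonyl)amino)butyl, or an amine or a carboxylic acid in place of the ((iodomethyl)carbonyl)amino group, lies outside what these four compounds can speak to.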